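From an inactive urea to an untested isoquinoline

This account rests on a few compounds, and the source may have more. Where it says the series, first, only, none or still open, it means among the compounds named here.

Compound 1 `CC1CCN(c2nc(C(F)(F)F)ccc2CNC(=O)Nc2ccc3ccccc3n2)CC1`: "not active" (no number reported)
Compound 2 `CC1CCN(c2nc(C(F)(F)F)ccc2CNC(=O)Nc2ccc3ccncc3c2)CC1`: 8.4 nM
Compound 3 `CC1CCN(c2nc(C(F)(F)F)ccc2CNC(=O)Nc2cnc3ccccc3c2)CC1`: 9.5 nM

Three ureas sharing one core have been tested in an assay on isolated protein for antagonist activity at transient receptor potential cation channel subfamily V member 1 (Homo sapiens), read by FLIPR; a lower number here means a stronger inhibitor, a higher number a weaker inhibitor. Compound 1 gives "not active" (no number reported), so there is no number for it, only the report that it did nothing measurable. Compound 2, in the same assay, gives 8.4 nM, and compound 3 gives 9.5 nM; the step of a 1.1-fold higher number from compound 2 to compound 3 (0.05 log units; within the scatter) shows that these two bicyclic groups behave alike.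

Compound 4 `CC1CCN(c2nc(C(F)(F)F)ccc2CNC(=O)Nc2cccc3cnccc23)CC1` is the next member. The change from compound 1 is isoquinolin-5-yl in place of quinolin-2-yl on an amide-type nitrogen. Going by the values given here, no measured step covers this exact swap. What the data show is that one bicyclic group on the urea nitrogen gave no activity, while two others gave strong inhibition within the scatter of each other. Compound 4 carries a third bicyclic group, so its outcome cannot be read off directly, and the chance that it again falls outside the measurable range is real.

On balance compound 4 is expected to be active, with an estimated value of 30 nM in this assay, within a wide range from 5 nM to 400 nM.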

Compound 4, inhibition constant: 0.2 nM
Compound 4: middle estimate off by 150-fold (2.18 log units), on the high side, outside the stated range (below it).
By their numbers in this assay, from the lowest: compound 4; then compounds 2 and 3 (each within the scatter of the next).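

The group on the amide-type nitrogen proved to be more than a choice between inactive and roughly equal, since isoquinolin-5-yl stands well apart in this assay from both other active groups (a 48-fold lower number from compound 3 to compound 4 (1.68 log units; beyond the scatter); a 42-fold lower number from compound 2 to compound 4 (1.62 log units; beyond the scatter)). Compound 4 has the same atoms and the same counts of rings, donors and acceptors as compound 1, so two groups that match on all these counts can still sit at opposite ends of this small set: one gives no measurable activity, the other the lowest number, though steps involving compound 1 cannot be read as it has no number. Nothing measured here accounts for this gap.

The compounds shown do not tell whether the ring nitrogen of isoquinolin-5-yl matters, a question that quinolin-5-yl or the all-carbon naphthalen-1-yl at the same place would address. They also leave open whether this gain holds only with the shared core of these ureas or would carry over if the trifluoromethyl group gave way to a chlorine atom.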